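Trimethoxyphenyl amides: unsaturated bromo chain on the carbonyl

The compounds below may be only part of what the source reports. "The series", "measured", "known", "first", "only" and "open" are said of these compounds alone.

Measured compounds in a functional assay on HCT-116 cells (Homo sapiens) for inhibition, read by MTT assay, with a stated time of 48 h; a lower number here means a stronger inhibitor, a higher number a weaker inhibitor:
- compound 1, `CCC/C=C/C(=O)N(Cc1ccc(OC)c(O)c1)c1cc(OC)c(OC)c(OC)c1`: 95 nM
- compound 2, `CCC(=O)N(Cc1ccc(OC)c(O)c1)c1cc(OC)c(OC)c(OC)c1`: 61 nM
- compound 3, `COc1ccc(CN(C(=O)CBr)c2cc(OC)c(OC)c(OC)c2)cc1O`: 68 nM

The three numbers sit close together. Compound 3 stands second highest of the three; its nearest neighbour is compound 2 and its furthest is compound 1, and both gaps lie within the scatter, as the steps of a 1.4-fold lower number from compound 1 to compound 3 (0.15 log units; within the scatter) and a 1.1-fold higher number from compound 2 to compound 3 (0.05 log units; within the scatter) show. Among the measured compounds shown here, the only variation so far is the group on the carbonyl carbon, and changing it from pent-1-en-1-yl to ethyl, a 1.6-fold lower number from compound 1 to compound 2 (0.19 log units; within the scatter), also stays within the scatter.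

Compound 4, `COc1ccc(CN(C(=O)/C=C/CBr)c2cc(OC)c(OC)c(OC)c2)cc1O`, is not yet measured. It differs from compound 3 as follows: 3-bromoprop-1-en-1-yl in place of bromomethyl on a carbonyl carbon. For the measured compounds named here, the steps that bear on this are those among compounds 1, 2 and 3, since compound 1 already carries an unsaturated chain on the carbonyl carbon and compound 3 carries the bromine; none of them moved the number beyond the scatter. No step beyond the scatter is therefore expected, a 1.2-fold higher number from compound 3 to compound 4 (0.07 log units; within the scatter), in this assay. Compound 4 is estimated at 80 nM, within 35 nM to 200 nM.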

Compound 4, half-maximal inhibitory concentration: 59 nM
Compound 4: the middle estimate sits 1.4-fold (0.13 log units) above what was measured; measured number inside the range.
By their numbers in this assay, from the lowest: compounds 4, 2, 3 and 1 (each within the scatter of the next).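

In this assay the move from bromomethyl to 3-bromoprop-1-en-1-yl on the carbonyl carbon gives a 1.2-fold lower number from compound 3 to compound 4 (0.06 log units; within the scatter) and so brings the double bond and the bromine together in one chain without a step beyond the scatter. The comparisons with the ethyl and pent-1-en-1-yl compounds read a 1.0-fold lower number from compound 2 to compound 4 (0.01 log units; within the scatter) and a 1.6-fold lower number from compound 1 to compound 4 (0.21 log units; within the scatter) and also stay within the scatter, so none of the four groups shown at this position separates from the others. No measurement given here bears on why this position responds so little.

On these data alone, whether an amine or a carboxylic acid at the end of the chain would give a step beyond the scatter stays open. So does the effect of a longer bromo chain, or of a chloro group in place of the bromo group.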